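Chloro to sulfanyl at the shared core: no measured step

The compounds below may be only part of what the source reports. "The series", "measured", "known", "first", "only" and "open" are said of these compounds alone.

compound 1 `N#CNc1nccc(-c2ccncc2)n1` — < 5%
compound 2 `CC(C)(C)c1ccnc(Cl)n1` — < 5%

In a functional assay on the whole organism for inhibition, with Rattus norvegicus as the target, with stated times of 1 h and 3.5 h, at a dose of 100 mg/kg by the oral route (a higher number here means more inhibition at the dose given (going by the name of the read-out), a lower number less inhibition), compound 1 gives < 5%, which is a limit of the assay and not a number. Compound 2 in this assay gives < 5%, likewise a limit. Compound 2 therefore stands at the limit that both shown values share (the limit of < 5% in this assay, at which 2 of the 2 values shown sit). Going by the values given here, no step between measured compounds exists in this set.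

Compound 3 `CC(C)(C)c1ccnc(S)n1` differs from compound 2 by sulfanyl in place of chloro on an aromatic carbon.

With both known values at the limit, the step of a number no lower from compound 2 to compound 3 (the limit leaves the size open) is expected to lie within the scatter, with no direction. Compound 3 is expected at 5%, within 0% to 20%.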

Compound 3, a percentage reported as inhibition, in the whole organism at one dose (the size of the read-out at that dose, not a potency): 22%
The estimate for compound 3 lay 17 percentage points below the measured number, outside the stated range (above it).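

Sulfanyl in place of chloro on an aromatic carbon gives a number at least 17 percentage points higher from compound 2 to compound 3 (beyond the scatter) in this assay. This position, between two ring nitrogen atoms, is therefore one where a single-atom change moves the read-out clear of the assay limit, which neither earlier compound showed. The true size of the step stays open because one end of it is a limit: the limit of < 5% in this assay, at which 2 of the 3 values shown sit.

As far as these compounds go, whether the effect is specific to sulfanyl remains open. An amine, a hydroxyl or a methylsulfanyl group at this position would show how narrow the requirement is.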